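Methoxy to Hydroxy on a Melanocortin Receptor Ligand

The source may hold more compounds than are shown below. What is called first, only, known or untested is meant among the compounds shown, and "the series" means these compounds.

Measured compounds:
compound 1, `COc1ccc(Br)cc1CCc1c(Cl)cccc1-c1nccn1C`, 300 nM
compound 2, `CCn1ccnc1-c1cccc(Cl)c1CCc1cc(Br)ccc1OC`, 310 nM

Compound 1 has been tested in an assay on isolated protein for binding affinity to Melanocortin receptor 4 (Homo sapiens) (on this read-out lower numbers stand for stronger inhibition and higher numbers for weaker inhibition), where it gives 300 nM, the lowest of the two numbers at hand; its neighbour compound 2 lies within the scatter of it, as the step of a 1.0-fold higher number from compound 1 to compound 2 (0.01 log units; within the scatter) shows. Within the data shown here, that step, methyl in place of hydrogen on a saturated chain carbon bound to an aromatic nitrogen, is the only change measured so far, and it left the number essentially unchanged.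

Compound 3, `Cn1ccnc1-c1cccc(Cl)c1CCc1cc(Br)ccc1O`, differs from compound 1 by hydrogen in place of methyl on an oxygen on an aromatic ring; one bond further out this reads methoxy to hydroxy. Among the measured compounds shown here, no measured step touches this oxygen, so the single step on record does not bear on the change directly, and it offers no reason to expect a shift in either direction beyond the scatter. The estimate for compound 3 in this assay is therefore 300 nM, within a range of 100 nM to 1000 nM. This estimate means a step of no change at the digits printed from compound 1 to compound 3 (within the scatter), expected to fall within the scatter.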

Compound 3, inhibition constant: 9300 nM
Beside the measured number, compound 3's estimate is 31-fold (1.49 log units) below it; measured number above the stated range.
By their numbers in this assay, from the lowest: compounds 1 and 2 (each within the scatter of the next); then compound 3.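

In this assay, among these compounds, the change from methoxy to hydroxy produces a large step (a 31-fold higher number from compound 1 to compound 3 (1.49 log units; beyond the scatter)), whereas the only earlier step, at the saturated chain carbon bound to an aromatic nitrogen, stayed within the scatter (a 1.0-fold higher number from compound 1 to compound 2 (0.01 log units; within the scatter)). The oxygen on the aromatic ring is therefore a place where the number responds strongly, and losing this one methyl is enough to weaken binding markedly on this read-out. Nothing at hand explains the size of this step.

The compounds shown leave open whether a larger group on this oxygen, such as ethyl or a longer chain, would keep the number of compound 1, and how an amine in place of the methoxy would read. They also leave open whether the same change on compound 2 would give a step of similar size.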